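Working notes: methoxy for methyl on the aryl

The compounds below may be only part of what the source reports. "The series", "measured", "known", "first", "only" and "open" are said of these compounds alone.

Compound 1 `Cc1ccc(-c2nn(-c3ccccc3)cc2C(=O)NOCc2ccccc2Cl)cc1` gives 4680 nM in a functional assay on HeLa cells (Homo sapiens) for antiproliferative activity, read by MTT assay, with a stated time of 48 h, in the presence of a further agent that is not named here; on this read-out lower numbers stand for stronger inhibition of growth and higher numbers for weaker inhibition of growth. Compound 2 `Cc1ccc(-c2nn(-c3ccccc3)cc2C(=O)NOCc2ccc(Cl)cc2Cl)cc1`, which carries a chloro in place of hydrogen on an aromatic carbon of the benzyl part, gives 2040 nM in this assay. The step of a 2.3-fold lower number from compound 1 to compound 2 (0.36 log units; beyond the scatter). Going by the values given here, compound 2 thus holds the lowest of the two numbers measured so far. Among the compounds with values here, compound 3 `COc1ccc(-c2nn(-c3ccccc3)cc2C(=O)NOCc2ccc(Cl)cc2Cl)cc1` differs from compound 2 by methoxy in place of methyl on an aromatic carbon, a change on a different ring from the one altered between compound 1 and compound 2. Within the data shown here, the only measured step, a 2.3-fold lower number from compound 1 to compound 2 (0.36 log units; beyond the scatter), concerns the benzyl ring and does not bear on the 4-methylphenyl group; no measured pair in this set touches that group. With no guidance from the series, the expected step of a 1.0-fold lower number from compound 2 to compound 3 (0.01 log units; within the scatter) in this assay is none beyond the scatter. Compound 3 is therefore estimated at 2000 nM, with a range from 700 nM to 6000 nM.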

Compound 3, concentration for 50% growth inhibition: 5750 nM
The estimate for compound 3 lay 2.9-fold (0.46 log units) below the measured number; the measured number falls inside the stated range.
By their numbers in this assay, from the lowest: compound 2; then compounds 1 and 3 (each within the scatter of the next).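

In this assay the group para to a large group on this aromatic ring is not silent: 4-methoxyphenyl in place of 4-methylphenyl gives a 2.8-fold higher number from compound 2 to compound 3 (0.45 log units; beyond the scatter) and so weakens growth inhibition, a change at a place the earlier pair did not touch. This step runs in the opposite direction to a 2.3-fold lower number from compound 1 to compound 2 (0.36 log units; beyond the scatter) on the benzyl ring, and both steps are modest, so both rings affect the read-out in this small set. Nothing on hand accounts for the step from methyl to methoxy.

From the compounds shown here alone, whether a chloro, a hydroxyl or an amine at this place would fall nearer to methyl or to methoxy stays open. Also open, going by these compounds, is whether the same step would appear with the benzyl group of compound 1.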